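The source may report more compounds than this note shows. Statements on the series, on what has been measured and on what is new or still open speak of the compounds shown alone.

Measured in a functional assay on MDA-MB-435 cells (Homo sapiens) for inhibition, read by sulforhodamine B assay, with a stated time of 48 h; on this read-out higher numbers stand for weaker inhibition and lower numbers for stronger inhibition:
- Compound 1 `COc1ccc(N(C)c2nc(C)nc3c2CCC3)cc1`: 7 nM
- Compound 2 `Cc1ccc(N(C)c2ncnc3c2CCC3)cc1`: "not determined" (no result reported)
- Compound 3 `Cc1ccc(N(C)c2nc(C)nc3c2CCC3)cc1`: 360 nM

Going by the values given here, compound 3, at 360 nM, holds the higher of the only two numbers in this assay, and compound 2 offers no number to compare. Compound 4 `CCOc1ccc(N(C)c2nc(C)nc3c2CCC3)cc1` is reached from compound 3 by ethoxy in place of methyl on an aromatic carbon, with ethoxy in place of methyl on an aromatic carbon, para to a large group. Among the compounds with values here, one measured step bears on this change: a 51-fold higher number from compound 1 to compound 3 (1.71 log units; beyond the scatter), which is large and beyond the scatter and comes from methyl in place of methoxy at that carbon. Compound 4 runs the opposite way, from methyl back to an alkoxy group, so a clear move to a lower number is expected in this assay. Within the data shown here, no ethoxy compound has been measured, so the full size of that step is not assumed. The expected change is a 9.0-fold lower number from compound 3 to compound 4 (0.95 log units; beyond the scatter). For compound 4 the estimated value is 40 nM, with an expected range from 8 nM to 200 nM.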

Compound 4, half-maximal inhibitory concentration: 15.1 nM
Compound 4: the middle estimate sits 2.6-fold (0.42 log units) above what was measured; the range from low to high includes it.
By their numbers in this assay, from the lowest: compound 1; then compound 4; then compound 3.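

In this assay, the drop on leaving methyl at this aromatic carbon, para to a large group, proves not to be confined to methoxy: ethoxy in place of methyl gives a 24-fold lower number from compound 3 to compound 4 (1.38 log units; beyond the scatter) and so recovers most of what compound 3 had lost. The recovery is not complete, since methyl in place of hydrogen on the saturated chain carbon bound to the oxygen gives a 2.2-fold higher number from compound 1 to compound 4 (0.33 log units; beyond the scatter) and this modest step is still beyond the scatter. Nothing given here accounts for either step.

As far as these compounds go, whether a propoxy group or a longer chain would move the number further in the same direction remains open. From the compounds shown here alone, it is also open whether an alkoxy oxygen is needed at all, as an amine or a chlorine at this carbon would show.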